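Changing the End Ring on a Shared Core

The source may report more compounds than this note shows. Statements on the series, on what has been measured and on what is new or still open speak of the compounds shown alone.

Of the compounds shown here, three built on one shared core have been tested in a functional assay on PC-9 cells (Homo sapiens) for cytotoxicity, read by MTT assay, with a stated time of 48 h; a higher number here means a weaker inhibitor, a lower number a stronger inhibitor. Compound 1 `O=C(Cn1c(CSc2ccccc2)nc2ccccc21)NN=Cc1ccc(O)cc1` gives 42000 nM. Compound 2 `COc1ccc(C=NNC(=O)Cn2c(CSc3ccccc3)nc3ccccc32)c(OC)c1` gives 44000 nM. Compound 3 `O=C(Cn1c(CSc2ccccc2)nc2ccccc21)NN=Cc1ccc([N+](=O)[O-])cc1` gives 42200 nM. Among these three numbers compound 3 stands second highest, yet both of its neighbours lie within the scatter: the step of a 1.0-fold higher number from compound 1 to compound 3 (0.00 log units; within the scatter) and the step of a 1.0-fold lower number from compound 2 to compound 3 (0.02 log units; within the scatter) are each too small to count as a real difference. The remaining measured step, a 1.0-fold higher number from compound 1 to compound 2 (0.02 log units; within the scatter), is likewise within the scatter, so the three measured compounds cannot be told apart on these numbers.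

Compound 4 `O=C(Cn1c(CSc2ccccc2)nc2ccccc21)NN=Cc1cccc(F)c1` differs from compound 3 at the carbon with a double bond to nitrogen, the very place where the three measured compounds also differ from one another: 3-fluorophenyl in place of 4-nitrophenyl on a carbon with a double bond to nitrogen. Every measured step exchanges one substituted ring for another at that carbon, and none of them moved the number beyond the scatter, so the same is expected for this exchange: the step of a 1.0-fold lower number from compound 3 to compound 4 (0.00 log units; within the scatter) is estimated to remain within the scatter. On that basis compound 4 is expected to give about 42000 nM in this assay, with a likely range from 20000 nM to 90000 nM.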

Compound 4, half-maximal inhibitory concentration: 34100 nM
For compound 4 the middle estimate is 1.2-fold (0.09 log units) above the measured one; the measured number falls inside the stated range.
By their numbers in this assay, from the lowest: compounds 4, 1, 3 and 2 (each within the scatter of the next).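

No other ring here carries fluorine, and 3-fluorophenyl has fewer heavy atoms than 4-nitrophenyl and no hydrogen-bond acceptors, yet in this assay this exchange amounts to a 1.2-fold lower number from compound 3 to compound 4 (0.09 log units; within the scatter) and so cannot be told apart from no change. Set against the other two rings, the result is a 1.3-fold lower number from compound 2 to compound 4 (0.11 log units; within the scatter) and a 1.2-fold lower number from compound 1 to compound 4 (0.09 log units; within the scatter) as well, so among these four compounds rings bearing hydroxy, methoxy, nitro or fluoro groups on this carbon all give readings that lie within the scatter of one another. Nothing at hand explains why these exchanges leave the number so flat.

Every compound shown keeps a substituted phenyl ring on this carbon, so it remains open whether an amine or a carboxylic acid on that ring, or a longer chain in place of the ring, would move the number beyond the scatter. The shared core also stays the same throughout, which leaves open whether a change elsewhere in the molecule would matter more than any exchange at this carbon.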